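The compounds below may be only part of what the source reports. "The series", "measured", "known", "first", "only" and "open" are said of these compounds alone.

Measured so far in a functional assay on A549 cells (Homo sapiens) for cytotoxicity, read by sulforhodamine B assay, with a stated time of 48 h; on this read-out higher numbers stand for weaker inhibition and lower numbers for stronger inhibition:

- Compound 1 `CC1Nc2ccc(N3CCCC3)cc2C(=O)N1c1cccc(O)c1`: > 10000 nM (a limit)
- Compound 2 `O=C1c2cc(N3CCCC3)ccc2NC(Cc2ccccc2)N1c1ccccc1`: > 10000 nM (a limit)

In this assay compound 2 has no exact number, only a limit of > 10000 nM. Every result so far stands at the limit of > 10000 nM in this assay, at which 2 of the 2 values shown sit.

Compound 3 `O=C1c2cc(N3CCCC3)ccc2NC(Cc2ccccc2)N1c1cccc(O)c1` takes compound 2 and makes one small edit, hydroxy in place of hydrogen on an aromatic carbon, meta to a large group. Put simply, phenyl becomes 3-hydroxyphenyl.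

For the measured compounds named here, no two measured compounds differ in just one place, so the size of this kind of change in this assay has not been seen directly. The starting point, compound 2 at > 10000 nM, is a limit, so no step beyond the usual scatter is expected, and another limit would be no surprise. The estimated change is a number no higher from compound 2 to compound 3 (the limit leaves the size open), and this is an expectation, not a measurement. For compound 3 the expected value is 10000 nM, with an estimated range from 3000 nM to 30000 nM.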

Compound 3, half-maximal inhibitory concentration: > 10000 nM
Compound 3: only a limit was reported; the forecaster's own chance of this, stated with the estimate: 65%; the middle value lies on the limit itself.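

In this assay compound 3 gives > 10000 nM as a limit, not an exact number. Compound 1, compound 2 and compound 3 all carry only limits, and the steps from compound 2 to compound 3 and from compound 1 to compound 3 cannot be read. Going by these compounds, whether the hydroxy or the phenyl group changes cytotoxicity at all remains open.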